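Replacing the nitro group of compound 3 with chloro

The source may report more compounds than this note shows. Statements on the series, on what has been measured and on what is new or still open speak of the compounds shown alone.

Of the compounds shown here, three on a shared core have numbers so far in a toxicity assay on cells (Macrophage, Mus musculus, strain BALB/c) for cytotoxicity, read by MTT assay (on this read-out lower numbers stand for stronger inhibition and higher numbers for weaker inhibition), on this read-out. Compound 1 `C=CCOc1cc(OC)c(C(=O)/C=C/c2ccccc2Br)c(OCC=C)c1` gives 5400 nM there, compound 2 `C=CCOc1cc(OC)c(C(=O)/C=C/c2ccccc2F)c(OCC=C)c1` gives 13300 nM and compound 3 `C=CCOc1cc(OC)c(C(=O)/C=C/c2ccc([N+](=O)[O-])cc2)c(OCC=C)c1` gives 13200 nM under the same conditions. Compound 3 therefore sits at the upper end of the three, and the numbers show a 1.0-fold lower number from compound 2 to compound 3 (0.00 log units; within the scatter) together with a 2.4-fold higher number from compound 1 to compound 3 (0.39 log units; beyond the scatter) as well.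

Compound 4 `C=CCOc1cc(OC)c(C(=O)/C=C/c2ccc(Cl)cc2)c(OCC=C)c1` has chloro in place of nitro on an aromatic carbon and has no number yet. Among the compounds with values here, no measured step makes this exact exchange, and no compound with chloro has been read. The nearest steps are small: fluoro in place of bromo gave a 2.5-fold higher number from compound 1 to compound 2 (0.39 log units; beyond the scatter) in the numbers, and the two steps into compound 3 are no wider. A small move toward a lower number is expected, resting on the two halogen cases, compound 1 with 5400 nM and compound 2 with 13300 nM on the same scale. The estimated step is a 1.5-fold lower number from compound 3 to compound 4 (0.17 log units; within the scatter) and would stay within the scatter. For compound 4 the estimated value is 9000 nM with an expected range from 4500 nM to 18000 nM in this measurement.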

Compound 4, half-maximal inhibitory concentration: 13000 nM
Compound 4: middle estimate off by 1.4-fold (0.16 log units), on the low side; measured number inside the range.
By their numbers in this assay, from the lowest: compound 1; then compounds 4, 3 and 2 (each within the scatter of the next).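

In this assay, within the data shown here, the first direct reading at this place, on an aromatic carbon para to a large group, shows that chloro in place of nitro leaves the number unchanged within the scatter (a 1.0-fold lower number from compound 3 to compound 4 (0.01 log units; within the scatter)), even though a single chlorine atom replaces a nitro group of three heavy atoms. The wider comparisons place 4-chlorophenyl level with 2-fluorophenyl (a 1.0-fold lower number from compound 2 to compound 4 (0.01 log units; within the scatter)) but apart from 2-bromophenyl (a 2.4-fold higher number from compound 1 to compound 4 (0.38 log units; beyond the scatter)), so compound 1 alone stands apart among the four, and compounds 2 and 4 show that a halogen on the ring does not by itself give the lower number. No measurement in hand accounts for the separate standing of compound 1.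

Going by these compounds, what remains open is whether the lower number of compound 1 belongs to bromo itself or to where bromo sits, a question that 4-bromophenyl or 2-chlorophenyl would address. On these data alone, it is also open how an amine or a carboxylic acid would read in place of chloro on this aromatic carbon.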